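Pyridinyl for methylphenyl on a pyrazole carboxylic acid core

The compounds below may be only part of what the source reports. "The series", "measured", "known", "first", "only" and "open" are said of these compounds alone.

Of the compounds shown here, three sharing one core have been measured in a functional assay on BJAB cells (Homo sapiens) for antiproliferative activity, with a stated time of 4 days; a higher number here means that more compound is needed for the effect, a lower number that less compound is needed. Compound 1 `Cc1ccc(-c2c(C)nn(-c3nc(-c4ccc(Cl)c(Cl)c4)c(SC(C)C)s3)c2C(=O)O)cc1` gives 3800 nM. Compound 2 `COc1cncc(-c2c(C)nn(-c3nc(-c4ccc(Cl)c(Cl)c4)c(SC(C)C)s3)c2C(=O)O)c1` gives 21000 nM, and compound 3 `Cc1cccc(-c2c(C)nn(-c3nc(-c4ccc(Cl)c(Cl)c4)c(SC(C)C)s3)c2C(=O)O)c1` gives 17000 nM. Compound 3 thus stands second highest of the three numbers, its nearest neighbour being compound 2, since a 1.2-fold lower number from compound 2 to compound 3 (0.09 log units; within the scatter), while against compound 1 the gap is larger: a 4.5-fold higher number from compound 1 to compound 3 (0.65 log units; beyond the scatter). The replacement of the pendant ring has mattered before, as a 5.5-fold higher number from compound 1 to compound 2 (0.74 log units; beyond the scatter).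

Compound 4 `Cc1nn(-c2nc(-c3ccc(Cl)c(Cl)c3)c(SC(C)C)s2)c(C(=O)O)c1-c1cccnc1` is the untested partner of compound 3, differing in one place: pyridin-3-yl in place of 3-methylphenyl on an aromatic carbon. Within the data shown here, no measured step repeats this exact exchange, but the step from compound 1 to compound 2 shows that a pyridinyl ring bearing a methoxy group lands close to where a methylphenyl lands in compound 3, so in this assay a step no larger than the scatter is expected here, as a 1.1-fold lower number from compound 3 to compound 4 (0.05 log units; within the scatter). Compound 4 is therefore estimated at 15000 nM, within 6000 nM to 40000 nM.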

Compound 4, half-maximal effective concentration: 12000 nM
For compound 4 the middle estimate is 1.3-fold (0.10 log units) above the measured one; low and high end bracket the measured number.
By their numbers in this assay, from the lowest: compound 1; then compounds 4, 3 and 2 (each within the scatter of the next).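

At this position, on the aromatic carbon next to the ring atom that bears a carboxy group, the plain pyridin-3-yl ring cannot be told apart in this assay from its two closest partners: there is a 1.4-fold lower number from compound 3 to compound 4 (0.15 log units; within the scatter) and also a 1.8-fold lower number from compound 2 to compound 4 (0.24 log units; within the scatter) for the loss of the methoxy group. Among these compounds, only the 4-methylphenyl ring stays apart, with a 3.2-fold higher number from compound 1 to compound 4 (0.50 log units; beyond the scatter) as the one step here that clears the scatter. Nothing measured here bears on why these rings fall as they do.

The compounds shown leave open whether the distance of compound 1 belongs to its 4-methylphenyl ring alone or would extend to a 4-chlorophenyl or an unsubstituted phenyl ring. They also leave open how a pyridin-4-yl ring would fall at this position.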